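The compounds below may be only part of what the source reports. "The series", "measured", "known", "first", "only" and "open" are said of these compounds alone.

Series of amides on a shared core. Compound 1 `O=C(Nc1cccc(-c2oc3cc(-c4ccc(F)cc4)ccc3c(=O)c2O)c1)c1ccc(Cl)cc1` gives 9140 nM in a functional assay on GTL 16 cells for antiproliferative activity against GTL 16 cell line (Homo sapiens), read by CCK-8 assay, with a stated time of 72 h; on this read-out higher numbers stand for weaker inhibition and lower numbers for stronger inhibition. Compound 2 `O=C(Nc1cccc(-c2oc3cc(-c4ccc(F)cc4)ccc3c(=O)c2O)c1)c1ccc(F)cc1F` gives 9640 nM in this assay. Compound 3 `Cc1cc(C(=O)Nc2cccc(-c3oc4cc(-c5ccc(F)cc5)ccc4c(=O)c3O)c2)ccc1F` gives 12100 nM in this assay. On these three numbers compound 2 stands second highest; its nearest neighbour is compound 1 and the further one is compound 3, and both gaps are within the scatter, so no order among the three can be read.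

The unmeasured compound 4 `COc1cc(OC)cc(C(=O)Nc2cccc(-c3oc4cc(-c5ccc(F)cc5)ccc4c(=O)c3O)c2)c1` differs from compound 2 only on the carbonyl carbon: 3,5-dimethoxyphenyl in place of 2,4-difluorophenyl on a carbonyl carbon.

Every measured step in this set is a swap of the aryl on the carbonyl carbon and none left the scatter: a 1.1-fold higher number from compound 1 to compound 2 (0.02 log units; within the scatter), a 1.3-fold higher number from compound 1 to compound 3 (0.12 log units; within the scatter), a 1.3-fold higher number from compound 2 to compound 3 (0.10 log units; within the scatter). On that basis the aryl swap to compound 4 is expected to give no step beyond the scatter in this assay; a move of roughly a 1.1-fold higher number from compound 2 to compound 4 (0.04 log units; within the scatter) is estimated. Compound 4 is expected to give about 10500 nM, from 5000 nM to 22000 nM.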

Compound 4, half-maximal inhibitory concentration: 19600 nM
Estimate against measurement, compound 4: 1.9-fold (0.27 log units) below; the measured number falls inside the stated range.
By their numbers in this assay, from the lowest: compounds 1, 2, 3 and 4 (each within the scatter of the next, the first and the last beyond it).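

Swaps at this position on the carbonyl carbon had so far stayed within the scatter, but 3,5-dimethoxyphenyl gives the first steps beyond it in this assay, towards weaker inhibition: in place of 2,4-difluorophenyl (a 2.0-fold higher number from compound 2 to compound 4 (0.31 log units; beyond the scatter)) and in place of 4-chlorophenyl (a 2.1-fold higher number from compound 1 to compound 4 (0.33 log units; beyond the scatter)), both modest. In place of 4-fluoro-3-methylphenyl the step stays within the scatter (a 1.6-fold higher number from compound 3 to compound 4 (0.21 log units; within the scatter)), so compound 4 separates from only two of the three earlier amides. Nothing at hand gives a measured reason for these steps.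

Whether the shift needs both methoxy groups remains open, as a single methoxy on the phenyl ring is not among the compounds shown. Also open, on these data alone, is how this position responds to an aryl bearing an amine or a carboxylic acid, or to a longer alkyl chain in place of the aryl.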